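Cyclopropylethynyl Gives Way to Phenylethenyl on the Core

The source may hold more compounds than are shown below. What is called first, only, known or untested is meant among the compounds shown, and "the series" means these compounds.

Compound 2 `Nc1ncnn2c([C@@H]3O[C@H](CO)[C@@H](O)[C@H]3O)cc(C#CC3CC3)c12` stands lowest of the two numbers shown in a functional assay on K562 cells (Homo sapiens) for antiproliferative activity, with a stated time of 72 h (a lower number here means a stronger inhibitor, a higher number a weaker inhibitor), where compound 2 gives 40 nM. Compound 1 `CCCC#Cc1cc([C@@H]2O[C@H](CO)[C@@H](O)[C@H]2O)n2ncnc(N)c12` gives 1100 nM, so that a 28-fold lower number from compound 1 to compound 2 (1.44 log units; beyond the scatter). Compound 3 `Nc1ncnn2c([C@@H]3O[C@H](CO)[C@@H](O)[C@H]3O)cc(C#Cc3ccc(F)cc3)c12` reaches only a limit of this assay, > 100000 nM. The change to compound 4 `Nc1ncnn2c([C@@H]3O[C@H](CO)[C@@H](O)[C@H]3O)cc(/C=C/c3ccccc3)c12` is 2-phenylethenyl in place of 2-cyclopropylethynyl on an aromatic carbon. For the measured compounds named here, the steps that bear on it are an at least 2500-fold higher number from compound 2 to compound 3 (3.39 log units; beyond the scatter) and an at least 90-fold higher number from compound 1 to compound 3 (1.95 log units; beyond the scatter); each brings a six-membered aromatic ring of carbon only to the same aromatic carbon, though through a triple bond rather than a double bond, and each was a large loss. A large step upward in this assay is therefore expected, a 500-fold higher number from compound 2 to compound 4 (2.70 log units; beyond the scatter). Compound 4 is estimated at 20000 nM, between 2000 nM and 100000 nM.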

Compound 4, half-maximal inhibitory concentration: 3100 nM
For compound 4 the middle estimate is 6.5-fold (0.81 log units) above the measured one, and the stated range covers the measured number.
By their numbers in this assay, from the lowest: compound 2; then compound 1; then compound 4. At a limit, above all of these: compound 3.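

An aromatic ring of carbon only on this aromatic carbon need not abolish activity in this assay: the 2-phenylethenyl group gives an at least 32-fold lower number from compound 3 to compound 4 (1.50 log units; beyond the scatter). The value of compound 3 is a limit, not a number: the limit of > 100000 nM in this assay, at which 1 of the 4 values shown sits.

The group still costs much against the best compound shown, with a 78-fold higher number from compound 2 to compound 4 (1.89 log units; beyond the scatter), and the loss is smaller against the open chain, with a 2.8-fold higher number from compound 1 to compound 4 (0.45 log units; beyond the scatter).

The compounds shown do not separate the double bond from the fluorine in the gap between compound 3 and compound 4. Going by these compounds, how an unsubstituted 2-phenylethynyl group, or an amine on the phenyl ring, would read stays open.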